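Swapping an ether for a small ring on a pyrimidine

A few compounds are considered here, and "the series" means these few. Any claim that something is new, unique, unknown or untested is made for them only; others in the source may bear on it.

Measured so far:
- Compound 1 `C[C@H]1CN(c2scnc2-c2nc3ccccc3[nH]2)CCN1C(=O)Cn1cnc2cccnc21`: 67 nM
- Compound 2 `CCOc1ncc(-c2nc(C(F)(F)F)sc2N2CCN(C(=O)Cn3nc(C)cc3C)[C@H](C)C2)cn1`: 2.3 nM
- Compound 3 `Cc1nc(C)n(CC(=O)N2CCN(c3sc(C(F)(F)F)nc3-c3cnc(OC(C)C)nc3)C[C@H]2C)n1`: 3.4 nM

These numbers come from a functional assay on CHO-K1 cells for antagonist activity at C-X-C chemokine receptor type 3 (Homo sapiens), read by FLIPR, with a stated time of 10 min; on this read-out lower numbers stand for stronger inhibition and higher numbers for weaker inhibition. Compound 3 stands second highest of the three; its number is close to that of compound 2, the two lying within the usual scatter, while compound 1 gives a clearly higher number, beyond the scatter.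

Compound 4 `Cc1nc(C)n(CC(=O)N2CCN(c3sc(C(F)(F)F)nc3-c3cnc(C4CC4)nc3)C[C@H]2C)n1` is not yet measured. It differs from compound 3 in one place: cyclopropyl in place of isopropoxy on an aromatic carbon. Among the measured compounds shown here, no measured pair shows this change, so its effect is unknown. The expected step from compound 3 to compound 4 is a 1.8-fold higher number from compound 3 to compound 4 (0.25 log units; within the scatter), a small shift toward a weaker number that may well stay within the scatter. For compound 4 the estimate in this assay is 6 nM, within 2 nM to 20 nM.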

Compound 4, half-maximal inhibitory concentration: 3.5 nM
Estimate against measurement, compound 4: 1.7-fold (0.23 log units) above, and the stated range covers the measured number.
By their numbers in this assay, from the lowest: compounds 2, 3 and 4 (each within the scatter of the next); then compound 1.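

In this assay, cyclopropyl in place of isopropoxy gives a 1.0-fold higher number from compound 3 to compound 4 (0.01 log units; within the scatter), so at this carbon between two ring nitrogen atoms the swap leaves the number within the scatter. In this one pair, a small carbon ring stands in for the ether, and losing its oxygen, the one hydrogen-bond acceptor of that group, causes no shift beyond the scatter. Nothing measured here explains this match. Going by these compounds, whether an amine or a carboxylic acid at this carbon would hold the number stays open. So does whether the same swap reads alike on another core.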